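A few compounds are considered here, and "the series" means these few. Any claim that something is new, unique, unknown or untested is made for them only; others in the source may bear on it.

Measured compounds in a functional assay on MCF7 cells (Homo sapiens) for inhibition, read by MTT assay, with a stated time of 72 h; a lower number here means a stronger inhibitor, a higher number a weaker inhibitor:
compound 1 `COc1ccc(Nc2nc(SCc3cn(Cc4ccccc4Cl)nn3)nc(-c3ccccc3)c2C#N)cc1` gives 8050 nM
compound 2 `N#Cc1c(Nc2ccccc2F)nc(SCc2cn(Cc3ccccc3Cl)nn2)nc1-c1ccccc1` gives 8060 nM
compound 3 `Cc1ccc(Nc2nc(SCc3cn(Cc4ccccc4Cl)nn3)nc(-c3ccccc3)c2C#N)cc1` gives 9420 nM

Compound 3 stands level with the other two: the steps of a 1.2-fold higher number from compound 1 to compound 3 (0.07 log units; within the scatter) and a 1.2-fold higher number from compound 2 to compound 3 (0.07 log units; within the scatter) both lie within the scatter, as does a 1.0-fold higher number from compound 1 to compound 2 (0.00 log units; within the scatter). All three compounds differ only in the group on the nitrogen on an aromatic ring, and none of these changes moved the number.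

Compound 4 `Cc1ccc(Nc2nc(SCc3cn(Cc4ccccc4Cl)nn3)nc(-c3ccc(Br)cc3)c2C#N)cc1` differs from compound 3 at another place: bromo in place of hydrogen on an aromatic carbon. Among the measured compounds shown here, no measured step touches the phenyl of the shared core, so nothing among the measured steps bears directly on this change. Given that every measured change left the number in place, compound 4 is expected to move only a 1.0-fold lower number from compound 3 to compound 4 (0.00 log units; within the scatter), within the scatter. For compound 4 the estimate in this assay is 9400 nM, in the range 4000 nM to 22000 nM.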

Compound 4, half-maximal inhibitory concentration: 25100 nM
Beside the measured number, compound 4's estimate is 2.7-fold (0.43 log units) below it; the whole stated range lies below it.
By their numbers in this assay, from the lowest: compounds 1, 2 and 3 (each within the scatter of the next); then compound 4.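

In this assay, the phenyl of the shared core turns out to be a place where the number responds: bromo in place of hydrogen, para to a large group, gives a 2.7-fold higher number from compound 3 to compound 4 (0.43 log units; beyond the scatter), whereas all the changes on the nitrogen stayed within the scatter. Phenyl to 4-bromophenyl is thus the only change here that weakens inhibition beyond the scatter. Nothing available accounts for this step. Going by these compounds, it remains open whether fluoro, methoxy or a carboxylic acid at this place would move the number likewise, and whether bromo would have the same effect with the 4-methoxyphenyl or 2-fluorophenyl group on the nitrogen.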